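Switching the propanoyl for butyl on the aromatic oxygen

A few compounds are considered here, and "the series" means these few. Any claim that something is new, unique, unknown or untested is made for them only; others in the source may bear on it.

Three compounds have been measured:
compound 1, `CCC(=O)Oc1ccc2oc(/C=C/[S+](C)[O-])cc(=O)c2c1`, 2400 nM
compound 2, `COc1ccc2c(=O)cc(/C=C/[S+](C)[O-])oc2c1`, 2200 nM
compound 3, `Cc1cccc2c(=O)cc(/C=C/[S+](C)[O-])oc12`, 1700 nM

All three values come from a functional assay on A549 cells (Homo sapiens) for cytotoxicity, with a stated time of 48 h; a higher number here means a weaker inhibitor, a lower number a stronger inhibitor. Compound 1 holds the highest number of the three, yet its neighbours sit close: compound 2 gives 2200 nM, and compound 3 gives 1700 nM, so both gaps to compound 1 fall within the scatter of repeated measurements, and no order among the three can be claimed.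

The step of interest leads from compound 1 to compound 4, `CCCCOc1ccc2oc(/C=C/[S+](C)[O-])cc(=O)c2c1`, which has not been measured in this assay. The difference between them is butyl in place of propanoyl on an oxygen on an aromatic ring. Cut one bond further out, it reads propanoyloxy to butoxy; the group that enters has no hydrogen-bond acceptor where the group that leaves had one.

Among the compounds with values here, no step between two measured compounds isolates this kind of change, so there is nothing in the measured set to say which way it should go. The three measured values are all close, and the expectation is therefore for a step of a 1.0-fold higher number from compound 1 to compound 4 (0.02 log units; within the scatter) in this assay, not beyond the scatter in either direction. Compound 4 is accordingly estimated at 2500 nM, with a range from 1200 nM to 5000 nM.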

Compound 4, half-maximal inhibitory concentration: 1400 nM
Estimate against measurement, compound 4: 1.8-fold (0.25 log units) above; the measured number falls inside the stated range.
By their numbers in this assay, from the lowest: compounds 4, 3, 2 and 1 (each within the scatter of the next).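

In this assay, within the data shown here, the only step read at this position, butyl in place of propanoyl on an oxygen on an aromatic ring, gives a 1.7-fold lower number from compound 1 to compound 4 (0.23 log units; within the scatter) and so stays within the scatter. The earlier compounds shown here held no such step; this one shows that, on the core of compound 1, a group with no hydrogen-bond acceptor can take the place of one that counts one without the number moving beyond the usual spread of repeated measurements. With no independent measurement on these compounds to draw on, nothing can be said about what lies behind this small step.

Going by these compounds, what remains open is whether the tolerance seen for this pair extends to other groups on the same oxygen, such as a longer chain like octyl, a chain ending in an amine, or one ending in a carboxylic acid. On these data alone, it also remains open whether a group on this oxygen can move the number beyond the scatter at all, since a single step within the scatter sets no limit in either direction.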